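The compounds below may be only part of what the source reports. "The series", "measured", "known", "first", "only" and "open" are said of these compounds alone.

Working notes on the diamino-substituted series sharing one core. In a functional assay on HT-29 cells (Homo sapiens) for antiproliferative activity, read by MTT assay, with a stated time of 72 h (a higher number here means a weaker inhibitor, a lower number a stronger inhibitor), compound 1 `Nc1nc(N)c2cc(CSC(=S)N3CCN(c4ccccc4)CC3)ccc2n1` gives 2760 nM, compound 2 `COc1ccc(N2CCN(C(=S)SCc3ccc4nc(N)nc(N)c4c3)CC2)cc1` gives 1770 nM, and compound 3 `Nc1nc(N)c2cc(CSC(=S)N3CCN(c4ccc(Cl)c(Cl)c4)CC3)ccc2n1` gives 3480 nM. On these numbers compound 2 stands lowest, its nearest neighbour being compound 1, with a 1.6-fold lower number from compound 1 to compound 2 (0.19 log units; within the scatter), and its furthest compound 3, with a 2.0-fold higher number from compound 2 to compound 3 (0.29 log units; within the scatter); the remaining pair shows a 1.3-fold higher number from compound 1 to compound 3 (0.10 log units; within the scatter). Compound 4 `Nc1nc(N)c2cc(CSC(=S)N3CCN(c4ncccn4)CC3)ccc2n1` differs from compound 2 by pyrimidin-2-yl in place of 4-methoxyphenyl on an amine nitrogen in a ring. The two steps that touch the same position, a 1.6-fold lower number from compound 1 to compound 2 (0.19 log units; within the scatter) and a 2.0-fold higher number from compound 2 to compound 3 (0.29 log units; within the scatter), both stay within the scatter, so no step beyond the scatter is expected in this assay here: a 1.4-fold higher number from compound 2 to compound 4 (0.15 log units; within the scatter) is the expected step. Compound 4 is therefore estimated at 2500 nM, with a range of 1200 nM to 5500 nM.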

Compound 4, half-maximal inhibitory concentration: 4720 nM
The estimate for compound 4 lay 1.9-fold (0.28 log units) below the measured number; low and high end bracket the measured number.
By their numbers in this assay, from the lowest: compounds 2, 1, 3 and 4 (each within the scatter of the next, the first and the last beyond it).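

In (this assay), the place on the amine nitrogen in a ring now gives its first step beyond the scatter, though a modest one (a 2.7-fold higher number from compound 2 to compound 4 (0.43 log units; beyond the scatter)). Pyrimidin-2-yl stays within the scatter against the other two groups (a 1.7-fold higher number from compound 1 to compound 4 (0.23 log units; within the scatter); a 1.4-fold higher number from compound 3 to compound 4 (0.13 log units; within the scatter)), so at this place only the change from 4-methoxyphenyl to pyrimidin-2-yl separates two compounds. Nothing on hand accounts for this step. Open, from the compounds shown here alone, is where pyridin-2-yl would fall at this place, with one ring nitrogen instead of two. Also open, going by these compounds, is whether a cyclohexyl group there would stay within this narrow spread.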